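Amide in place of ester on a shared core

This account rests on a few compounds, and the source may have more. Where it says the series, first, only, none or still open, it means among the compounds named here.

Compound 1 has the structure `COC(=O)c1nc(Br)c2cccnc2c1N[C@H]1CC[C@H](N)CC1`. In a functional assay on HCT-116 cells (Homo sapiens) for cytotoxicity, read by MTT assay, with a stated time of 72 h (a higher number here means a weaker inhibitor, a lower number a stronger inhibitor), compound 1 gives "not determined" (no result reported), so no number stands for it, and the rest of the picture comes from two relatives. Compound 2, `O=C(NCCCNc1c(C(=O)NCc2ccc(F)cc2)nc(Br)c2cccnc12)c1ccccc1`, gives > 10000 nM in this assay, which is a limit of the assay and not a number. Compound 3, `O=C(NCc1ccc(F)cc1)c1nc(Br)c2cccnc2c1NCc1ccc(F)cc1`, gives > 20000 nM in this assay, again a limit rather than a number. For the measured compounds named here, the one change between them, a step that the two limits leave unreadable from compound 2 to compound 3, therefore cannot be read in size.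

Compound 4, `C[C@H](NC(=O)c1nc(Br)c2cccnc2c1N[C@H]1CC[C@H](N)CC1)c1ccc(F)cc1`, differs from compound 1 by (1-(4-fluorophenyl)ethyl)amino in place of methoxy on a carbonyl carbon. Going by the values given here, no measured step touches this carbonyl position, and the two measured relatives sit only at limits, so nothing here sets a direction or a size for the step from compound 1 to compound 4 beyond the scatter. Given that both measured relatives sit at limits in this assay, compound 4 is expected to land near the weak end as well, estimated at 8000 nM with a range from 1500 nM to 40000 nM.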

Compound 4, half-maximal inhibitory concentration: > 10000 nM
Compound 4: only a limit was reported (the forecaster's own chance of this, stated with the estimate: 55%); at least 1.2-fold (0.09 log units) between middle value and limit.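

No new step can be read from compound 1 to compound 4, as neither has a number in this assay: compound 4 sits only at a limit. The compounds shown leave open whether (1-(4-fluorophenyl)ethyl)amino in place of methoxy changes activity at all.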